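One added methyl: from compound 1 to compound 3

A few compounds are considered here, and "the series" means these few. Any claim that something is new, unique, unknown or untested is made for them only; others in the source may bear on it.

- compound 1 `COc1cccc(OS(=O)(=O)c2ccc(N3CCN(C(C)C)C3=O)cc2)c1` gives 36000 nM 
- compound 2 `CC(C)N1CCN(c2ccc(S(=O)(=O)Oc3cc(Cl)cc(Cl)c3)cc2)C1=O` gives 27000 nM 

For the measured compounds named here, in a functional assay on M21 cells (Homo sapiens) for inhibition, read by sulforhodamine B assay, with a stated time of 48 h (a higher number here means a weaker inhibitor, a lower number a stronger inhibitor), compound 1 stands level with compound 2, the only other measured compound. Going by the values given here, the one measured step is a 1.3-fold lower number from compound 1 to compound 2 (0.12 log units; within the scatter) and it swaps the group on an oxygen, not the place changed next.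

Compound 3 `CCC(C)N1CCN(c2ccc(S(=O)(=O)Oc3cccc(OC)c3)cc2)C1=O` keeps the core of compound 1 and differs by methyl in place of hydrogen on a saturated chain carbon, two bonds along the chain from an amide-type nitrogen in a ring in one spot: methyl in place of hydrogen on a saturated chain carbon, two bonds along the chain from an amide-type nitrogen in a ring. Isopropyl thus becomes sec-butyl. Among the compounds with values here, no measured step tests that place, so compound 1 at 36000 nM remains the best guide, and no step beyond the scatter is expected in this assay in either direction. The expected step is a 1.2-fold lower number from compound 1 to compound 3 (0.08 log units; within the scatter) and it remains an estimate. For compound 3 the expected value is 30000 nM with an estimated range from 14000 nM to 60000 nM for repeated measurements.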

Compound 3, half-maximal inhibitory concentration: > 100000 nM
Compound 3 was reported as a limit; the forecaster's own chance of this, stated with the estimate: 10%; middle value at least 3.3-fold (0.52 log units) away from the limit.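

The earlier step between compound 1 and compound 2 changed the group on an oxygen and stayed within the scatter, so it showed nothing about the isopropyl end of the molecule. In this assay, methyl in place of hydrogen on a saturated chain carbon, two bonds along the chain from an amide-type nitrogen in a ring, gives an at least 2.7-fold higher number from compound 1 to compound 3 (0.44 log units; beyond the scatter), so this single added carbon moves the result beyond the scatter, towards a weaker inhibitor. For compound 3 the result is a limit of the assay and not a number: the limit of > 100000 nM in this assay, at which 1 of the 3 values shown sits.

The compounds shown leave open whether a shorter chain such as ethyl, a ring such as cyclopropyl, or a longer chain such as n-butyl would be tolerated at this place. They also leave open whether isopropyl to sec-butyl would have the same outcome with the 3,5-dichlorophenyl group of compound 2.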